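The compounds below may be only part of what the source reports. "The series", "measured", "known", "first", "only" and "open" are said of these compounds alone.

Measured so far:
compound 1, `COc1ccc(-n2c(SCc3ccccc3)nnc2-c2cc(OC)c(OC)c(OC)c2)cc1`, > 60000 nM
compound 2, `COc1cc(-c2nnc(SCc3ccccc3)n2-c2ccc(N(C)C)cc2)cc(OC)c1OC`, > 60000 nM

In a functional assay on HepG2 cells (Homo sapiens) for inhibition, read by MTT assay, with a stated time of 48 h (on this read-out lower numbers stand for stronger inhibition and higher numbers for weaker inhibition), compound 1 returns only a limit, > 60000 nM. In this assay compound 2 likewise returns only a limit, > 60000 nM. Going by the values given here, the one step measured between them, a step that the two limits leave unreadable from compound 1 to compound 2, is therefore unreadable: both values sit at the limit of > 60000 nM in this assay, at which 2 of the 2 values shown sit, so nothing can be said about the size or direction of that change.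

Compound 3, `COc1cc(-c2nnc(SCC(=O)C3CC3)n2-c2ccc(N(C)C)cc2)cc(OC)c1OC`, differs from compound 2 in one place: cyclopropylcarbonyl in place of phenyl on a saturated chain carbon bound to a sulfur. Among the compounds with values here, no measured step bears on this change, since the only pair of measured compounds differs elsewhere and both of its members stand at the limit. The expectation for compound 3 in this assay rests only on the standing of compound 2, which returns a limit of > 60000 nM in that assay. With no readable step in the series, compound 3 is expected to stand where compound 2 stands, that is, most likely again at the limit, and the estimated step of a number no higher from compound 2 to compound 3 (the limit leaves the size open) is accordingly expected to be none that can be read. Compound 3 is thus estimated at 60000 nM, with a range from 8000 nM to 200000 nM.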

Compound 3, half-maximal inhibitory concentration: > 60000 nM
Compound 3: a limit, no number (the forecaster's own chance of this, stated with the estimate: 70%); the middle value lies on the limit itself.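

No step can be read from compound 2 to compound 3 in this assay, since both stand only at a limit: the limit of > 60000 nM in this assay, at which 3 of the 3 values shown sit.

The compounds shown leave open whether any change to the shared core, or any other group on the saturated chain carbon bound to a sulfur, would give a measurable number in this assay.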